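This account rests on a few compounds, and the source may have more. Where it says the series, first, only, none or still open, it means among the compounds named here.

Compound 1 `CCOC(=O)c1cc(=O)c2cc(CSC(=S)N(C(C)C)C(C)C)ccc2o1` in a functional assay on LM7 cells (Homo sapiens) for antiproliferative activity, read by MTT assay, with a stated time of 72 h (a higher number here means a weaker inhibitor, a lower number a stronger inhibitor), gives a value that is a limit of the assay, > 25000 nM. Compound 2 `CCOC(=O)c1cc(=O)c2cc(CSC(=S)N(C)c3ccccc3)ccc2o1` in this assay likewise gives only a limit, > 25000 nM. Compound 3 `CCOC(=O)c1cc(=O)c2cc(CSC(=S)N3CCCCC3)ccc2o1` in this assay gives 16900 nM.

Among these three, compound 3 holds the only real number; the other two values sit at the limit of > 25000 nM in this assay, at which 2 of the 3 values shown sit. The step that the two limits leave unreadable from compound 1 to compound 2 therefore gives no reading at all.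

Compound 4 `CCOC(=O)c1cc(=O)c2cc(CSC(=S)N3CCOCC3)ccc2o1` differs from compound 3 by morpholin-4-yl in place of piperidin-1-yl on a thiocarbonyl carbon. For the measured compounds named here, no measured pair swaps this group for a morpholinyl, so the only guidance comes from the steps into compound 3: an at least 1.4-fold lower number from compound 1 to compound 3 (0.17 log units; that floor lies within the scatter) and an at least 1.4-fold lower number from compound 2 to compound 3 (0.17 log units; that floor lies within the scatter), both mere floors that lie within the scatter. On that basis no step beyond the scatter is expected in this assay, in either direction. The expected step from compound 3 to compound 4 is a 1.2-fold higher number from compound 3 to compound 4 (0.07 log units; within the scatter). Compound 4 is accordingly estimated at 20000 nM in this assay, within 8000 nM to 50000 nM, with a real chance that only a limit is reported.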

Compound 4, half-maximal inhibitory concentration: > 25000 nM
Compound 4 ended at the assay's limit; the forecaster's own chance of this, stated with the estimate: 40%; middle value at least 1.2-fold (0.09 log units) from the limit.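

In this assay, morpholin-4-yl in place of piperidin-1-yl on a thiocarbonyl carbon gives an at least 1.4-fold higher number from compound 3 to compound 4 (0.17 log units; that floor lies within the scatter), so this swap brings no gain, though its true size cannot be read. The swap keeps the six-membered non-aromatic ring and adds one hydrogen-bond acceptor, yet compound 4 gives only a limit of the assay, so this ring oxygen does not yield a readable number here. The steps into compound 4 from compound 1 and from compound 2 cannot be read, and compound 3 alone holds a real number: the limit of > 25000 nM in this assay, at which 3 of the 4 values shown sit.

On these data alone, whether a smaller ring such as pyrrolidin-1-yl or a 4-methylpiperazin-1-yl group on the same carbon would give a readable number stays open. So does the effect of a carboxylic acid in place of the ethyl ester on the shared core.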